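A Further Methoxy Group on the Side Arm

A few compounds are considered here, and "the series" means these few. Any claim that something is new, unique, unknown or untested is made for them only; others in the source may bear on it.

compound 1 `Nc1cc(N)c2nc(-c3ccccc3)c(NCc3ccc(Cl)c(Cl)c3)nc2c1`: 30900 nM
compound 2 `COc1ccc(CNc2nc3cc(N)cc(N)c3nc2-c2ccccc2)cc1OC`: 26300 nM

In a functional assay on UACC-62 cells (Homo sapiens) for inhibition, read by sulforhodamine B assay, with a stated time of 48 h (a higher number here means a weaker inhibitor of growth, a lower number a stronger inhibitor of growth), compound 1 gives 30900 nM and compound 2 gives 26300 nM. Among the compounds with values here, the only measured step, a 1.2-fold lower number from compound 1 to compound 2 (0.07 log units; within the scatter), lies within the scatter, so compound 2 does not stand apart from compound 1. Compound 3 `COc1cc(CNc2nc3cc(N)cc(N)c3nc2-c2ccccc2)cc(OC)c1OC` differs from compound 2 by methoxy in place of hydrogen on an aromatic carbon. Within the data shown here, no measured step adds a methoxy group; the single step available exchanged groups on that same ring and changed little. Compound 3 is therefore expected to show a 1.1-fold lower number from compound 2 to compound 3 (0.02 log units; within the scatter), with an estimate of 25000 nM in the range 10000 nM to 60000 nM.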

Compound 3, concentration for total growth inhibition: 15500 nM
For compound 3 the middle estimate is 1.6-fold (0.21 log units) above the measured one, within the range that was stated.
By their numbers in this assay, from the lowest: compounds 3, 2 and 1 (each within the scatter of the next).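

Adding a methoxy group on this aromatic carbon, ortho to a methoxy group and meta to a large group, gives a 1.7-fold lower number from compound 2 to compound 3 (0.23 log units; within the scatter) in this assay, so compound 3 does not stand apart from compound 2. Within the data shown here, this is the first measured addition to the ring, and it stays within the scatter, as did the exchange of groups before it. No evidence available here bears on this result. The compounds shown leave open whether a hydroxyl group or an amine at this position, or a longer chain linking this ring to the core, would give a step beyond the scatter.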